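Chloro for methyl, moved from one ring to the other

The compounds below may be only part of what the source reports. "The series", "measured", "known", "first", "only" and "open" are said of these compounds alone.

Compound 1 `Cc1ccc(-c2csc(NC(=O)COc3ccc(F)cc3F)n2)cc1` gives 14500 nM in a functional assay on MCF7 cells (Homo sapiens) for cytotoxicity, read by MTT assay, with a stated time of 48 h; on this read-out higher numbers stand for weaker inhibition and lower numbers for stronger inhibition. Compound 2 `O=C(COc1ccc(F)cc1F)Nc1nc(-c2ccc(Cl)cc2)cs1` carries chloro in place of methyl on an aromatic carbon and gives 25800 nM in this assay, a step of a 1.8-fold higher number from compound 1 to compound 2 (0.25 log units; within the scatter). Compound 3 `Cc1ccc(OCC(=O)Nc2nc(-c3ccc(C)cc3)cs2)cc1` differs from compound 1 by 4-methylphenyl in place of 2,4-difluorophenyl on an oxygen on a saturated carbon; in this assay compound 3 gives 41300 nM, a step of a 2.8-fold higher number from compound 1 to compound 3 (0.45 log units; beyond the scatter). Compound 4 `Cc1ccc(-c2csc(NC(=O)COc3ccc(Cl)cc3)n2)cc1` is not yet measured and carries chloro in place of methyl on an aromatic carbon. The place is described in the same words for both changes, although cut one bond further out the change in compound 4 reads 4-methylphenoxy to 4-chlorophenoxy rather than 4-methylphenyl to 4-chlorophenyl. Compound 4 is expected to show a 1.3-fold higher number from compound 3 to compound 4 (0.12 log units; within the scatter) because the same change gave a 1.8-fold higher number from compound 1 to compound 2 (0.25 log units; within the scatter). Compound 4 is therefore estimated at 55000 nM in this assay, with a range of 25000 nM to 120000 nM.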

Compound 4, half-maximal inhibitory concentration: 43800 nM
The estimate for compound 4 lay 1.3-fold (0.10 log units) above the measured number, and the stated range covers the measured number.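

In this assay, chloro in place of methyl on an aromatic carbon gives a 1.1-fold higher number from compound 3 to compound 4 (0.03 log units; within the scatter), and the change carries over between the two cores without a shift that can be told from noise: the same change on two cores in this assay, a 1.8-fold higher number (0.25 log units; within the scatter) from compound 1 to compound 2 and a 1.1-fold higher number (0.03 log units; within the scatter) from compound 3 to compound 4, 1.7-fold (0.22 log units) apart, within the scatter of two such steps. This rests on a single pair of steps, each within the scatter, so it shows neither a real effect of chloro over methyl nor how the change would behave on a third core. The one larger move among the new steps is 4-chlorophenyl in place of 2,4-difluorophenyl on the oxygen, a 3.0-fold higher number from compound 1 to compound 4 (0.48 log units; beyond the scatter).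

Going by these compounds, whether an amine or a carboxylic acid at that aromatic carbon would move the number in this assay stays open, as does a longer chain in place of the methyl.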